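This account rests on a few compounds, and the source may have more. Where it says the series, first, only, none or still open, it means among the compounds named here.

Working notes on the series. In a functional assay on MDA-MB-231 cells (Homo sapiens) for cytotoxicity, read by MTT assay, with a stated time of 48 h (on this read-out lower numbers stand for stronger inhibition and higher numbers for weaker inhibition), compound 2 (`COc1ccc(-c2nnnn2-c2cc(OC)c(OC)c(OC)c2)cc1N`) gives 3170 nM, compound 1 (`COc1ccc(C2=NOC(COc3ccc(-c4nnnn4-c4cc(OC)c(OC)c(OC)c4)cc3N)C2)cc1N`) gives 3000 nM and compound 3 (`COc1cc(C2=NOC(COc3ccc(-c4nnnn4-c4cc(OC)c(OC)c(OC)c4)cc3N)C2)ccc1O`) gives 3620 nM. Compound 2 therefore stands within the scatter of both other compounds, and the three values set no order among them.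

Compound 4 (`COc1cc(-n2nnnc2-c2ccc(OCC3CC(c4ccccc4F)=NO3)c(N)c2)cc(OC)c1OC`) departs from compound 2 by one structural change: a group of 12 heavy atoms (9 carbon, 1 nitrogen, 1 oxygen, 1 fluorine; one five-membered non-aromatic ring with 2 hetero atoms, one six-membered aromatic ring of carbon only) in place of a hydrogen atom, on a saturated chain carbon bound to an oxygen on an aromatic ring. Compound 1 and compound 3 also carry a five-membered non-aromatic ring and a six-membered aromatic ring in a group at that place, but without fluorine. Among the measured compounds shown here, the only measured step between such compounds, a 1.2-fold higher number from compound 1 to compound 3 (0.08 log units; within the scatter), exchanges 4-hydroxy-3-methoxyphenyl for 3-amino-4-methoxyphenyl and lies within the scatter. The values of compound 1 and compound 3 also show no gap beyond the scatter from that of compound 2. For the measured compounds named here, no measured compound carries fluorine, so the range stays wide.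

The expected change in this assay is a 1.0-fold higher number from compound 2 to compound 4 (0.00 log units; within the scatter), which means no step beyond the scatter and no favoured direction. For compound 4 the estimated value is 3200 nM, with an expected range of 1500 nM to 6500 nM.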

Compound 4, half-maximal inhibitory concentration: 2400 nM
The estimate for compound 4 lay 1.3-fold (0.12 log units) above the measured number, and the stated range covers the measured number.
By their numbers in this assay, from the lowest: compounds 4, 1, 2 and 3 (each within the scatter of the next).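

In this assay, the group of 12 heavy atoms carrying fluorine, in place of a hydrogen atom on a saturated chain carbon bound to an oxygen on an aromatic ring, gives a 1.3-fold lower number from compound 2 to compound 4 (0.12 log units; within the scatter), so this first fluorine-bearing group also adds no step beyond the scatter at this place. On the carbon with a double bond to nitrogen, 2-fluorophenyl in place of 4-hydroxy-3-methoxyphenyl gives a 1.5-fold lower number from compound 3 to compound 4 (0.18 log units; within the scatter), and 2-fluorophenyl in place of 3-amino-4-methoxyphenyl gives a 1.3-fold lower number from compound 1 to compound 4 (0.10 log units; within the scatter), so three different aryl groups on that carbon now stand within the scatter of one another, whether they carry fluorine, a hydroxy group or an amino group. No measurement on hand offers an explanation for this flat picture.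

The compounds shown leave open whether any group on the carbon with a double bond to nitrogen can move the number beyond the scatter, as every group there so far is a substituted phenyl ring. A carboxylic acid, a tertiary amine or a plain methyl on that carbon would test this, and a longer chain in place of the saturated chain carbon would test the link itself.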